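Replacing Cyano with Amino on a Shared Core

The compounds below may be only part of what the source reports. "The series", "measured", "known", "first", "only" and "open" are said of these compounds alone.

Within the data shown here, in a functional assay on MC-38 cells (Mus musculus) for antiproliferative activity (on this read-out lower numbers stand for stronger inhibition and higher numbers for weaker inhibition), compound 1 (`COc1ccc(S(=O)(=O)Nc2cccc3c(Cl)c[nH]c23)cc1`) gives 0.2 ug/mL and compound 2 (`N#Cc1ccc(S(=O)(=O)Nc2cccc3c(Cl)c[nH]c23)cc1`) gives 0.13 ug/mL so compound 2 stands within the usual scatter of its only measured neighbour. Compound 3 (`Nc1ccc(S(=O)(=O)Nc2cccc3c(Cl)c[nH]c23)cc1`) carries amino in place of cyano on an aromatic carbon, para to a large group (amino in place of cyano on an aromatic carbon). Among the measured compounds shown here, one measured step bears on this carbon: cyano in place of methoxy (a 1.5-fold lower number from compound 1 to compound 2 (0.19 log units; within the scatter)) and that step stayed within the scatter. In this assay the expected result is therefore no step beyond the scatter, with an estimated 1.2-fold higher number from compound 2 to compound 3 (0.09 log units; within the scatter) in size. For compound 3 the estimated value is 0.16 ug/mL (0.05 ug/mL to 0.5 ug/mL).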

Compound 3, half-maximal inhibitory concentration: 0.23 ug/mL
Beside the measured number, compound 3's estimate is 1.4-fold (0.16 log units) below it, and the stated range covers the measured number.
By their numbers in this assay, from the lowest: compounds 2, 1 and 3 (each within the scatter of the next).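

Across this assay, this aromatic carbon, para to a large group, now carries three different groups, and both new steps stay within the scatter: amino in place of cyano (a 1.8-fold higher number from compound 2 to compound 3 (0.25 log units; within the scatter)) and amino in place of methoxy (a 1.2-fold higher number from compound 1 to compound 3 (0.06 log units; within the scatter)). Amino brings a hydrogen-bond donor that cyano lacks, yet that swap produces no step beyond the scatter. No measurement offers an explanation for these numbers. The compounds shown leave open whether a carboxylic acid or a longer chain on this carbon would move the number beyond the scatter.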